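Series notes: substitution alpha to the amine in compound 1

A few compounds are considered here, and "the series" means these few. Any claim that something is new, unique, unknown or untested is made for them only; others in the source may bear on it.

The anchor of the series is compound 1 `CSCC[C@H](NC(=O)c1ccc(CNCCC2CCCCC2)cc1-c1ccccc1C)C(=O)O`. Going by the values given here, in a functional assay for inhibition, with Rattus norvegicus as the target (a lower number here means that less compound is needed, a higher number that more compound is needed for the effect), compound 1 gives 200 nM, and it is the only full number in the set. Compound 2 `CC[C@H](CC1CCCCC1)NCc1ccc(C(=O)N[C@@H](CCSC)C(=O)O)c(-c2ccccc2C)c1` carries ethyl in place of hydrogen on a saturated chain carbon bound to an amine nitrogen and a saturated chain carbon. In this assay compound 2 gives > 1000 nM, which is a limit of the assay rather than a number. The step is an at least 5.0-fold higher number from compound 1 to compound 2 (0.69 log units; beyond the scatter), and the evidence behind it is the limit of > 1000 nM in this assay, at which 1 of the 2 values shown sits.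

Compound 3 `CSCC[C@H](NC(=O)c1ccc(CN[C@H](CSc2ccccc2)CC2CCCCC2)cc1-c1ccccc1C)C(=O)O` is not yet measured. It differs from compound 1 at the same position: (phenylsulfanyl)methyl in place of hydrogen on a saturated chain carbon bound to an amine nitrogen and a saturated chain carbon. Among the compounds with values here, the only measured step that bears on this change is the one from compound 1 to compound 2, which adds ethyl at this position and lands on the limit. A larger group in the same place is therefore expected to move the number in the same direction, upward, beyond the scatter, and a limit readout is a real possibility. For compound 3 the expected step is a 10-fold higher number from compound 1 to compound 3 (1.00 log units; beyond the scatter). In this assay compound 3 is estimated at 2000 nM, within a range of 500 nM to 8000 nM.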

Compound 3, half-maximal effective concentration: 12 nM
Estimate against measurement, compound 3: 170-fold (2.22 log units) above; the measured number lies below the stated range.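

The substitution on the saturated chain carbon bound to an amine nitrogen and a saturated chain carbon does not push the number in one direction: in this assay, (phenylsulfanyl)methyl gives a 17-fold lower number from compound 1 to compound 3 (1.22 log units; beyond the scatter), while ethyl gave an at least 5.0-fold higher number from compound 1 to compound 2 (0.69 log units; beyond the scatter). Phenylsulfanyl in place of methyl on a saturated chain carbon, two bonds along the chain from an amine nitrogen, gives an at least 83-fold lower number from compound 2 to compound 3 (1.92 log units; beyond the scatter), so the outcome at this position depends on which group enters and not on substitution as such. Compound 2 sits at a limit of the assay, so this last step is a bound and not a full measure of the change: the limit of > 1000 nM in this assay, at which 1 of the 3 values shown sits.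

The compounds shown do not separate the contributions of the sulfur, the aromatic ring and the length of the entering group; phenoxymethyl, benzyl and (cyclohexylsulfanyl)methyl at this position would each address a different part of that question. Also open, from the compounds shown here alone, is whether the lower number in compound 3 holds with the opposite configuration at this carbon.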